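The compounds below may be only part of what the source reports. "The series", "measured", "known", "first", "only" and "open" are said of these compounds alone.

Measured so far in an assay on HeLa cells for displacement of a labelled ligand from adenosine receptor A3 (Homo sapiens), with a stated time of 180 min, tested at 1 uM; on this read-out lower numbers stand for less inhibition and higher numbers for more inhibition at the one concentration tested (going by the name of the read-out):

compound 1 `CC1=C(C(=O)OC(C)C)C(c2ccsc2)N/C(=N/C#N)N1` – 13%
compound 2 `CCOC(=O)C1=C(C)N/C(=N\C#N)NC1c1ccsc1` – 23%

Both compounds share one core and are read on this assay at a single concentration. Within the data shown here, compound 1 stands as the lower of the two numbers, with compound 2 as its only neighbour, a number 10 percentage points higher from compound 1 to compound 2 (within the scatter). That single step, hydrogen in place of methyl on a saturated chain carbon bound to an oxygen next to a carbonyl group, stayed inside the usual scatter.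

Compound 3 `CC1=C(C(=O)OC(C)C)C(c2ccccc2)N/C(=N/C#N)N1` is not yet measured. It differs from compound 1 by phenyl in place of thiophen-3-yl on a saturated ring carbon. Among the measured compounds shown here, no measured step touches this part of the molecule, since the only known step concerns the saturated chain carbon and not the aromatic ring, so there is no basis for expecting a shift beyond the scatter in this assay. Compound 3 is therefore expected to give about 14%, within 0% to 35%. The expected step is a number 1 percentage points higher from compound 1 to compound 3 (within the scatter), with the real measurement still to come.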

Compound 3, a percentage reported as inhibition, at one concentration (the size of the read-out at that concentration, not a potency): 6%
Beside the measured number, compound 3's estimate is 8 percentage points above it; the range from low to high includes it.
By their numbers in this assay, from the lowest: compounds 3, 1 and 2 (each within the scatter of the next, the first and the last beyond it).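

Measured in this assay the swap of thiophen-3-yl for phenyl on the saturated ring carbon gives a number 7 percentage points lower from compound 1 to compound 3 (within the scatter) and this is the only step shown at this position. With the isopropoxycarbonyl group held the same, replacing a five-membered aromatic ring containing sulfur with a six-membered aromatic ring of carbon only leaves the read-out within the usual scatter. No measurement shown here offers an explanation for this result.

As far as these compounds go, it remains open whether a different kind of group on this ring carbon, such as a cyclohexyl ring, a pyridine ring or an amine, would move the number beyond the scatter. From the compounds shown here alone, it is also open whether phenyl and thiophen-3-yl would compare in the same way alongside the ethoxycarbonyl group of compound 2.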